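Benzothiazole substituent swap: chloro to methoxy in compound 4

The compounds below may be only part of what the source reports. "The series", "measured", "known", "first", "only" and "open" are said of these compounds alone.

Going by the values given here, compound 3 `CS(=O)(=O)c1ccc(Nc2nccc(Nc3nc4ccc(Cl)cc4s3)n2)cc1` stands lowest among the three measured members, giving 1400 nM in a functional assay on HeLa cells (Homo sapiens) for antiproliferative activity, read by MTT assay, with a stated time of 48 h; on this read-out lower numbers stand for stronger inhibition and higher numbers for weaker inhibition; compound 1 `CS(=O)(=O)c1ccc(Nc2nccc(Nc3nc4ccccc4s3)n2)cc1` gives 11300 nM and compound 2 `COc1ccc2nc(Nc3nc(Nc4ccc(S(C)(=O)=O)cc4)ncc3F)sc2c1` gives 25400 nM. The step of an 8.1-fold lower number from compound 1 to compound 3 (0.91 log units; beyond the scatter) is the only one that bears on the next change, (methoxy in place of chloro on an aromatic carbon), giving compound 4 `COc1ccc2nc(Nc3ccnc(Nc4ccc(S(C)(=O)=O)cc4)n3)sc2c1`. Compound 4 keeps the core of compound 3 but trades the chloro that carried that gain for methoxy. Among the compounds with values here, compound 2, which carries methoxy at the same place together with a fluoro elsewhere, shows a much higher number than compound 3, although no single step links them. Compound 4 is therefore expected to move back toward the weaker end, by a 5.7-fold higher number from compound 3 to compound 4 (0.76 log units; beyond the scatter), with an estimated 8000 nM in this assay, ranging from 2500 nM to 25000 nM.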

Compound 4, half-maximal inhibitory concentration: 4130 nM
Compound 4: the middle estimate sits 1.9-fold (0.29 log units) above what was measured, and the stated range covers the measured number.
By their numbers in this assay, from the lowest: compound 3; then compound 4; then compound 1; then compound 2.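

In this assay methoxy at this carbon still improves on hydrogen, with a 2.7-fold lower number from compound 1 to compound 4 (0.44 log units; beyond the scatter) and yet falls short of chloro, with a 3.0-fold higher number from compound 3 to compound 4 (0.47 log units; beyond the scatter) so the order at this place runs chloro, then methoxy, then hydrogen. With methoxy held in place, hydrogen in place of fluoro gives a 6.2-fold lower number from compound 2 to compound 4 (0.79 log units; beyond the scatter) and so the fluoro alone separates the two methoxy compounds. Nothing on hand explains this order.

As far as these compounds go, whether an amine, a carboxylic acid or a longer chain at this carbon would match chloro stays open, as does the effect of fluoro on the chloro compound.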